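The compounds below may be only part of what the source reports. "The series", "measured", "known", "first", "only" and "open" are said of these compounds alone.

Measured compounds:
Compound 1, `COc1cc(C(=O)Nc2nn[nH]n2)nc(-c2ccccc2)c1`, gives 100% in a functional assay on the whole organism for inhibition, with Rattus norvegicus as the target, at a dose of 10 mg/kg by the oral route; on this read-out higher numbers stand for a stronger effect at the one dose given and lower numbers for a weaker effect.
Compound 2, `CCCCc1ccc(-c2cc(OC)cc(C(=O)Nc3nn[nH]n3)n2)cc1`, gives 92% in this assay.
Compound 3, `COc1cc(C(=O)Nc2nn[nH]n2)nc(-c2ccc(NC(C)=O)cc2)c1`, gives 100% in this assay.

Compound 1 stands level with compound 3 at the digits reported, and together they are the highest of the three numbers; the gap to compound 2 is a number 8 percentage points lower from compound 1 to compound 2 (within the scatter), and no change at the digits printed from compound 1 to compound 3 (within the scatter). All three measured steps change the group on the phenyl ring, so a number 8 percentage points higher from compound 2 to compound 3 (within the scatter) is likewise within the scatter. Compound 4, `O=C(Nc1nn[nH]n1)c1cccc(-c2ccccc2)n1`, differs from compound 1 at a different place: hydrogen in place of methoxy on an aromatic carbon. Within the data shown here, none of the measured steps touches this position, so the three steps give no direct guidance on the size of the change, only the observation that the shared core kept its read-out through every change tried so far. The step is therefore expected to be a number 15 percentage points lower from compound 1 to compound 4 (beyond the scatter), with wide uncertainty. Compound 4 is estimated to give 85% in this assay, within a range from 55% to 100%.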

Compound 4, a percentage reported as inhibition, in the whole organism at one dose (the size of the read-out at that dose, not a potency): 81%
Estimate against measurement, compound 4: 4 percentage points above; measured number inside the range.
By their numbers in this assay, from the lowest: compound 4; then compounds 2, 1 and 3 (each within the scatter of the next).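

In this assay, hydrogen in place of methoxy opposite the ring nitrogen gives a number 19 percentage points lower from compound 1 to compound 4 (beyond the scatter) and is the first step shown that lies beyond the scatter. Among these compounds, the earlier steps all changed the substituent on the phenyl group and all stayed within the scatter, so this position is the first place where the read-out is seen to move, although compound 4 still gives 81% at the one dose. Nothing at hand accounts for this step.

The compounds shown leave open whether a hydroxyl, an amine or a longer ether such as ethoxy at this position would keep the read-out of compound 1. They also leave open whether the step would be the same size with butyl or acetamido on the phenyl group.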